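Methyl on the core and antiproliferative potency

This account rests on a few compounds, and the source may have more. Where it says the series, first, only, none or still open, it means among the compounds named here.

Measured compounds:
compound 1, `COc1cc(CC(O)(COCc2ccccc2)COCc2ccccc2)nc(OC)n1`, in a functional assay on HepG2 cells (Homo sapiens) for antiproliferative activity, read by MTT assay, with a stated time of 72 h; a higher number here means a weaker inhibitor, a lower number a stronger inhibitor: > 100000 nM, a limit of the assay
compound 2, `COc1nc(CC(O)(COCc2ccccc2)COCc2ccccc2)c(C)c(OC)n1`, in this assay: 2400 nM
compound 3, `C[Si](C)(C)CCOCn1c(CC(O)COCc2ccccc2)cc(=O)[nH]c1=O`, in this assay: > 100000 nM, a limit of the assay

Compound 1 gives only a limit in this assay, not a number. Compound 2 gives a number, and the step of an at least 41-fold lower number from compound 1 to compound 2 (1.61 log units; beyond the scatter) goes with the change (methyl in place of hydrogen on an aromatic carbon). Compound 3 likewise gives only a limit. Two of the three values thus sit at the limit of > 100000 nM in this assay, at which 2 of the 3 values shown sit.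

Compound 4, `Cc1c(CC(O)COCc2ccccc2)n(COCC[Si](C)(C)C)c(=O)[nH]c1=O`, is not yet measured. Its change from compound 3 is methyl in place of hydrogen on an aromatic carbon. It is the same kind of change as from compound 1 to compound 2, not the same change: in compound 4 the entering group is ortho to a group of 1 heavy atom, meta to a group of 8 heavy atoms and para to a group of 1 heavy atom, whereas in compound 2 it is ortho to a methoxy group and para to a methoxy group. The difference between the core of compound 1 and the core of compound 3 is not broken down here.

The expectation for compound 4 rests on the step of an at least 41-fold lower number from compound 1 to compound 2 (1.61 log units; beyond the scatter), which was large, and on the limit given by compound 3. Because of the limit of > 100000 nM in this assay, at which 2 of the 3 values shown sit, the starting point for compound 4 is only known as a limit, so the expected step is set smaller than the measured one: for compound 4 the estimated step is an at least 3.3-fold lower number from compound 3 to compound 4 (0.52 log units; beyond the scatter). Compound 4 is thus expected at about 30000 nM, between 6000 nM and 100000 nM.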

Compound 4, half-maximal inhibitory concentration: > 100000 nM
Compound 4 ended at the assay's limit; the forecaster's own chance of this, stated with the estimate: 40%; middle value at least 3.3-fold (0.52 log units) from the limit.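

Compound 3 and compound 4 both give only a limit in this assay, so no step can be read between them: the limit of > 100000 nM in this assay, at which 3 of the 4 values shown sit.

The compounds shown leave open whether methyl in place of hydrogen on an aromatic carbon changes activity at all on the core of compound 3, where the same kind of change on the core of compound 1 went with an at least 41-fold lower number from compound 1 to compound 2 (1.61 log units; beyond the scatter).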